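Adding one carbon to the amine chain of compound 3

A few compounds are considered here, and "the series" means these few. Any claim that something is new, unique, unknown or untested is made for them only; others in the source may bear on it.

In a functional assay on LS174T cells (Homo sapiens) for antiproliferative activity (a lower number here means a stronger inhibitor, a higher number a weaker inhibitor), compound 1 `CNc1ccc(/C=C/c2c(F)cccc2Cl)cc1` gives 7.6 nM and compound 2 `CNc1ccc(/C=C/c2c(Cl)cccc2Cl)cc1` gives 50.1 nM. Compound 3 `CNc1ccc(/C=C/c2c(F)cccc2F)cn1` gives 30.1 nM, which lies within the scatter of the number for compound 2 and beyond the scatter above the number for compound 1. Compound 4 `CCNc1ccc(/C=C/c2c(F)cccc2F)cn1` differs from compound 3 by methyl in place of hydrogen on a saturated chain carbon bound to a nitrogen on an aromatic ring, so that methylamino becomes ethylamino. For the measured compounds named here, no measured step alters this chain. Going by the values given here, the only step available, a 6.6-fold higher number from compound 1 to compound 2 (0.82 log units; beyond the scatter), comes from a different change, chloro in place of fluoro on an aromatic carbon, and it serves only as a rough gauge of size. A large shift is therefore not expected, and the direction remains uncertain. The expected change is small, a 1.3-fold higher number from compound 3 to compound 4 (0.12 log units; within the scatter), and this estimate does not clearly leave the scatter. Compound 4 is expected at 40 nM, with an estimated range of 14 nM to 120 nM.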

Compound 4, half-maximal inhibitory concentration: 31.3 nM
For compound 4 the middle estimate is 1.3-fold (0.11 log units) above the measured one; the range from low to high includes it.
By their numbers in this assay, from the lowest: compound 1; then compounds 3, 4 and 2 (each within the scatter of the next).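

In this assay the added methyl gives a 1.0-fold higher number from compound 3 to compound 4 (0.02 log units; within the scatter), so methylamino and ethylamino cannot be told apart in this pair. For the compounds shown here, this is the first reading at the saturated chain carbon bound to a nitrogen on an aromatic ring, since the earlier step, between compound 1 and compound 2, concerned chloro in place of fluoro on an aromatic carbon, and it shows that this position holds one added carbon with the number staying within the scatter. No available evidence accounts for this result.

As far as these compounds go, whether a longer chain such as propyl, a branched chain such as isopropyl, or an unsubstituted amine would also stay within the scatter remains open. Also open, from the compounds shown here alone, is whether the same methyl would give a similar step on the core of compound 1.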